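A few compounds are considered here, and "the series" means these few. Any claim that something is new, unique, unknown or untested is made for them only; others in the source may bear on it.

In a functional assay on HT-29 cells (Homo sapiens) for antiproliferative activity, read by MTT assay, with a stated time of 96 h (on this read-out higher numbers stand for weaker inhibition and lower numbers for stronger inhibition), the measured compounds stand as follows:
compound 1 `COc1ccc(N2C(=O)NC3(CSC4=C3C(=O)c3ncccc3C4=O)C2=O)cc1` gives 2 nM;
compound 2 `O=C1C2=C(C(=O)c3ncccc31)C1(CS2)NC(=O)N(c2ccccc2)C1=O` gives 2 nM;
compound 3 `CCN(CC)c1ccc(N2C(=O)NC3(CSC4=C3C(=O)c3ncccc3C4=O)C2=O)cc1` gives 50 nM.

Compound 3 thus has the highest number of the three, the diethylamino compound standing apart from both companions: a 25-fold higher number from compound 1 to compound 3 (1.40 log units; beyond the scatter) and a 25-fold higher number from compound 2 to compound 3 (1.40 log units; beyond the scatter), while no change at the digits printed from compound 1 to compound 2 (within the scatter). Compound 4 `Cc1ccc(N2C(=O)NC3(CSC4=C3C(=O)c3ncccc3C4=O)C2=O)cc1` differs from compound 3 by methyl in place of diethylamino on an aromatic carbon. Both large steps bear on this change, since each removes or installs diethylamino at the same aromatic carbon, and methoxy and hydrogen there gave the same low number. Replacing diethylamino with methyl is therefore expected to reverse that loss, so that a 17-fold lower number from compound 3 to compound 4 (1.22 log units; beyond the scatter) is expected. Compound 4 is estimated at 3 nM, with a range of 1 nM to 10 nM.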

Compound 4, half-maximal inhibitory concentration: 1 nM
Beside the measured number, compound 4's estimate is 3.0-fold (0.48 log units) above it; the range from low to high includes it.
By their numbers in this assay, from the lowest: compounds 4, 1 and 2 (each within the scatter of the next); then compound 3.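

With methyl on this aromatic carbon, para to a large group, the number falls back to the low level (a 50-fold lower number from compound 3 to compound 4 (1.70 log units; beyond the scatter)), so the loss belongs to diethylamino and not to every substituent there. Methyl also stays level with the other two groups (a 2.0-fold lower number from compound 2 to compound 4 (0.30 log units; within the scatter); a 2.0-fold lower number from compound 1 to compound 4 (0.30 log units; within the scatter)), leaving diethylamino as the only one of the four that stands apart. Nothing measured here gives a reason for this.

From the compounds shown here alone, whether a plain amine, dimethylamino or a longer chain such as butyl would bring the same loss stays open.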